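The compounds below may be only part of what the source reports. "The series", "measured", "known", "first", "only" and "open" are said of these compounds alone.

Measured so far:
Compound 1 `CC1=NN(C(=O)c2cc3ccccc3oc2=O)C(=O)C1CNc1ccc(S(N)(=O)=O)cc1`: 68.9%
Compound 2 `CC1=NN(C(=O)c2cc3ccccc3oc2=O)C(=O)C1CNc1c(O)cc(S(=O)(=O)O)c2ccccc12`: 21.6%

In a functional assay on the whole organism for inhibition, with Rattus norvegicus as the target, read by paw edema, with stated times of 1 h and 4 h, at a dose of 0.03 mg/kg by the oral route (a lower number here means less inhibition, a higher number more inhibition at the dose given (going by the name of the read-out)), compound 1 gives 68.9%, the higher of the two numbers. Going by the values given here, compound 2 gives 21.6%, a number that lies beyond the scatter below that of compound 1; compound 2 differs from compound 1 in more than one place, so no single step is drawn between them.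

Compound 3 `COc1ccc(NCC2C(=O)N(C(=O)c3cc4ccccc4oc3=O)N=C2C)cc1` has not yet been measured in this assay. It differs from compound 1 in one place: methoxy in place of sulfamoyl on an aromatic carbon. Among the compounds with values here, no measured pair shows this change on its own, so its size can only be estimated. Compound 1 carries the highest number seen, which leaves more room downward than upward; the expected step from compound 1 to compound 3 is a number 13.9 percentage points lower from compound 1 to compound 3 (beyond the scatter), a moderate decrease that may or may not exceed the scatter. Compound 3 is therefore expected to give about 55%, within a range from 30% to 75%.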

Compound 3, a percentage reported as inhibition, in the whole organism at one dose (the size of the read-out at that dose, not a potency): 36.1%
The estimate for compound 3 lay 18.9 percentage points above the measured number; measured number inside the range.
By their numbers in this assay, from the lowest: compound 2; then compound 3; then compound 1.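

Methoxy in place of sulfamoyl, on an aromatic carbon of a six-membered aromatic ring of carbon only and para to a large group, gives a number 32.8 percentage points lower from compound 1 to compound 3 (beyond the scatter) in this assay. Going by these compounds alone, this is the first change read on its own at this position, and it shows that, with the core of compound 1 held fixed, the group here alone can shift the inhibition at this dose by a large amount, although compound 3 still gives 36.1%. Nothing measured here explains the step.

A single pair cannot separate the loss of sulfamoyl from the arrival of methoxy. Going by these compounds, it also remains open whether an amine, a carboxylic acid or a plain hydrogen at this position would stand nearer to compound 1 or to compound 3.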